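A Second Fluoro on Compound 2

This account rests on a few compounds, and the source may have more. Where it says the series, first, only, none or still open, it means among the compounds named here.

Within the data shown here, in a functional assay on HeLa cells (Homo sapiens) for antiproliferative activity, read by cell counting, with a stated time of 4 days (a higher number here means a weaker inhibitor, a lower number a stronger inhibitor), compound 2 (`CCOC(=O)CN(Cc1cccc(F)c1)c1ccc2c(c1)N(C)CC(C)(COc1ccc(C(=N)N)cc1)O2`) gives 4600 nM, the only actual number so far. Compound 1 (`CCOC(=O)CN(Cc1cc(F)cc(F)c1)c1ccc2c(c1)N(C)CC(C)(COc1ccc(C#N)cc1)O2`) reads > 100000 nM, which is a limit of the assay. Compound 3 (`CCOC(=O)CN(Cc1cc(F)cc(F)c1)c1ccc2c(c1)N(C)CC(C)(COc1ccc(C(=N)N)cc1)O2`) differs from compound 2 by one change, (fluoro in place of hydrogen on an aromatic carbon), which turns 3-fluorobenzyl into 3,5-difluorobenzyl. With compound 2 at 4600 nM as the only anchor, no step beyond the scatter is expected in this assay. The estimated change runs a 1.2-fold lower number from compound 2 to compound 3 (0.06 log units; within the scatter). Compound 3 is expected at 4000 nM, with an estimated range of 1500 nM to 12000 nM.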

Compound 3, half-maximal inhibitory concentration: 4500 nM
Compound 3: middle estimate off by 1.1-fold (0.05 log units), on the low side; the range from low to high includes it.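

In this assay, the 3,5-difluorobenzyl group reads the same as 3-fluorobenzyl, so this position takes a second fluoro with a step of a 1.0-fold lower number from compound 2 to compound 3 (0.01 log units; within the scatter). With 3,5-difluorobenzyl present in both compounds, the group at the other end of the molecule carries the large step, an at least 22-fold lower number from compound 1 to compound 3 (1.34 log units; beyond the scatter). The reading of compound 1 is a limit and not a number, so that step gives only a minimum: the limit of > 100000 nM in this assay, at which 1 of the 3 values shown sits.

From the compounds shown here alone, whether a chloro or a methoxy at this ring position would also read the same remains open. So does whether an amine in place of the fluoro would.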